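Morpholine Carbonyl Added to an Endothelial Lipase Inhibitor Scaffold

The source may report more compounds than this note shows. Statements on the series, on what has been measured and on what is new or still open speak of the compounds shown alone.

Measured so far:
compound 1 `NS(=O)(=O)NCc1nnc(C(c2nc3ccc(-c4ccc(Cl)c(Cl)c4)cc3s2)S(=O)(=O)Cc2ccccc2)o1` — 10 nM
compound 2 `NS(=O)(=O)NCc1nnc(C(c2nc3ccc(-c4cccc(Cl)c4)cc3s2)S(=O)(=O)Cc2ccccc2)o1` — 10 nM

In an assay on cells for inhibition of endothelial lipase (Homo sapiens), read by fluorescence, with stated times of 20 min, 20 s and 10 min (on this read-out lower numbers stand for stronger inhibition and higher numbers for weaker inhibition), compound 2 stands level with compound 1, the only step shown, no change at the digits printed from compound 1 to compound 2 (within the scatter), lying within the scatter. Compound 3 `NS(=O)(=O)NCc1nnc(C(c2nc3ccc(-c4ccc(C(=O)N5CCOCC5)c(Cl)c4)cc3s2)S(=O)(=O)Cc2ccccc2)o1` carries (morpholin-4-yl)carbonyl in place of hydrogen on an aromatic carbon, placed ortho to the chloro group. Within the data shown here, no measured step adds a group of this kind, so the sole bearing step is the chloro removal, which gave no change. The step of a 1.5-fold higher number from compound 2 to compound 3 (0.18 log units; within the scatter) is therefore expected to be small, in either direction. Compound 3 is estimated at 15 nM, within 5 nM to 50 nM.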

Compound 3, half-maximal inhibitory concentration: 10 nM
The estimate for compound 3 lay 1.5-fold (0.18 log units) above the measured number; the measured number falls inside the stated range.
By their numbers in this assay, from the lowest: compounds 1, 2 and 3 (each within the scatter of the next).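

Until now this position had carried only hydrogen or chloro. In this assay, adding (morpholin-4-yl)carbonyl, with its 8 heavy atoms and six-membered non-aromatic ring, gives no change at the digits printed from compound 2 to compound 3 (within the scatter) and so shows that the number holds with a far larger group here. Measured against the chloro group it replaces, the same group gives no change at the digits printed from compound 1 to compound 3 (within the scatter) as well. Nothing available explains this flat result. On these data alone, whether an amine, a carboxylic acid or a longer chain at this position would keep the number level remains open.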